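A few compounds are considered here, and "the series" means these few. Any claim that something is new, unique, unknown or untested is made for them only; others in the source may bear on it.

Compound 3 `CS(=O)(=O)N1CCN(C(=O)CN2CN(c3ccccc3)C3(CCN(C(=O)c4ccc(C5CCCCC5)cc4)CC3)C2=O)CC1` is the weakest of the three measured compounds in an assay on HEK293 cells for displacement of a labelled ligand from NPC1-like intracellular cholesterol transporter 1 (Homo sapiens) (a lower number here means a stronger inhibitor, a higher number a weaker inhibitor), where compound 3 gives 6300 nM. The two others share its core and differ from it only in the group attached to the carbonyl carbon of the side chain. Compound 1 `O=C(CN1CN(c2ccccc2)C2(CCN(C(=O)c3ccc(C4CCCCC4)cc3)CC2)C1=O)N1CCC(CO)CC1` gives 1100 nM and compound 2 `COC(=O)CCCNC(=O)CN1CN(c2ccccc2)C2(CCN(C(=O)c3ccc(C4CCCCC4)cc3)CC2)C1=O` gives 2500 nM; the steps are a 5.7-fold higher number from compound 1 to compound 3 (0.76 log units; beyond the scatter) and a 2.5-fold higher number from compound 2 to compound 3 (0.40 log units; beyond the scatter), both beyond the scatter, so compound 3 clearly sits at the top of the range.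

Compound 4 `O=C(CN1CN(c2ccccc2)C2(CCN(C(=O)c3ccc(C4CCCCC4)cc3)CC2)C1=O)NCO` alters the same position once more: (hydroxymethyl)amino in place of 4-(methylsulfonyl)piperazin-1-yl on a carbonyl carbon. All three measured steps bear on this change, since each of them swaps the group on that carbonyl carbon: a 2.3-fold higher number from compound 1 to compound 2 (0.36 log units; beyond the scatter), a 5.7-fold higher number from compound 1 to compound 3 (0.76 log units; beyond the scatter) and a 2.5-fold higher number from compound 2 to compound 3 (0.40 log units; beyond the scatter). The entering group is small and brings hydrogen-bond donors, as does the 4-(hydroxymethyl)piperidin-1-yl group of compound 1, which gave the lowest number of the three. Compound 4 is expected to give a lower number than compound 3, with the step estimated as a 4.2-fold lower number from compound 3 to compound 4 (0.62 log units; beyond the scatter). The estimated value for compound 4 is 1500 nM, with a range from 500 nM to 5000 nM.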

Compound 4, half-maximal inhibitory concentration: 8300 nM
Compound 4: the middle estimate sits 5.5-fold (0.74 log units) below what was measured, outside the stated range (above it).
By their numbers in this assay, from the lowest: compound 1; then compound 2; then compounds 3 and 4 (each within the scatter of the next).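

In this assay, size alone does not set the number at this position: the change from the ring-bearing 4-(methylsulfonyl)piperazin-1-yl group to the much smaller, ring-free (hydroxymethyl)amino group gives a 1.3-fold higher number from compound 3 to compound 4 (0.12 log units; within the scatter). A hydroxymethyl group on the carbonyl carbon is also not enough for a low number, as both end groups here carry one and yet the step is a 7.5-fold higher number from compound 1 to compound 4 (0.88 log units; beyond the scatter), and the ester-bearing chain goes the other way with a 3.3-fold higher number from compound 2 to compound 4 (0.52 log units; beyond the scatter), where hydroxy replaces 2-(methoxycarbonyl)ethyl on a saturated chain carbon bound to an amide-type nitrogen. No measurement here accounts for why these groups fall in this order.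

On these data alone, it remains open whether the piperidine ring of compound 1 matters more than its hydroxymethyl group, which a plain piperidin-1-yl group on the same carbonyl carbon could help to separate. As far as these compounds go, it is equally open whether the hydroxyl of compound 4 would behave differently at the end of a longer chain, such as 3-hydroxypropylamino, or whether a carboxylic acid in place of the methyl ester of compound 2 would shift the number.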